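A phenyl swap among compounds held at a limit

This account rests on a few compounds, and the source may have more. Where it says the series, first, only, none or still open, it means among the compounds named here.

In an ADME assay on L6 cells (Rattus norvegicus) for cytotoxicity, read by fluorescence and resazurin assay, with a stated time of 72 h (on this read-out higher numbers stand for an effect only at larger amounts of compound and lower numbers for an effect already at smaller amounts), compound 2 `O=c1nc(-c2ccccc2)c2cc(-c3ccccc3)ccc2[nH]1` gives > 50000 nM, a limit and not a number. Compound 1 `Cc1ccncc1-c1ccc2[nH]c(=O)nc(-c3ccccc3)c2c1` gives > 50000 nM, again a limit. Compound 3 `CNC(=O)c1cccc(-c2ccc3[nH]c(=O)nc(-c4ccccc4)c3c2)c1` gives > 50000 nM, also a limit. The measured series therefore rests entirely on (the limit of > 50000 nM in this assay, at which 3 of the 3 values shown sit), and compound 2 has no exact value from which to count.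

The step followed here leads to compound 4 `O=c1nc(-c2ccccc2)c2cc(-c3cc[nH]n3)ccc2[nH]1`, with 1H-pyrazol-3-yl in place of phenyl on an aromatic carbon.

Going by the values given here, two measured steps bear on this change. The first exchanges 4-methylpyridin-3-yl for phenyl on an aromatic carbon and is a step that the two limits leave unreadable from compound 1 to compound 2. The second puts methylcarbamoyl in place of hydrogen on an aromatic carbon and is a step that the two limits leave unreadable from compound 2 to compound 3. Neither offers a size to carry over, but neither change brought a number within reach in this assay.

The expectation is therefore no change beyond the usual scatter, and the expected step is a number no higher from compound 2 to compound 4 (the limit leaves the size open). Compound 4 is expected most likely to be reported at the same limit. For compound 4 the estimated value is 50000 nM, with an expected range from 20000 nM to 80000 nM.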

Compound 4, half-maximal effective concentration: > 50000 nM
Compound 4: no number, only a limit; the forecaster's own chance of this, stated with the estimate: 75%; the middle value sits exactly at the limit.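

In this assay, going by these compounds alone, compound 4 gives > 50000 nM, a limit and not a number, so no step from compound 1 or compound 2 to compound 4 can be read. The whole series now rests on one limit: the limit of > 50000 nM in this assay, at which 4 of the 4 values shown sit.

The compounds shown leave open how compound 1, compound 2, compound 3 and compound 4 rank in this assay, and at what amount any of them would show an effect.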